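From a carboxamide back to a sulfonamide

The source may hold more compounds than are shown below. What is called first, only, known or untested is meant among the compounds shown, and "the series" means these compounds.

Of the compounds shown here, three sharing one core have been tested in an assay on a protein complex (Cavia porcellus) with sulfonylurea receptors; K-ATP channels (Homo sapiens) as the target; a lower number here means a stronger inhibitor, a higher number a weaker inhibitor. Compound 1 `CN(C)S(=O)(=O)c1ccc(NC(=O)C(C)(O)C(F)(F)F)cc1` gives 480 nM in this assay. Compound 2 `CCN(CC)C(=O)c1ccc(NC(=O)C(C)(O)C(F)(F)F)cc1` reaches only the limit of this assay, > 30000 nM, which is not a number. Compound 3 `CC(O)(C(=O)Nc1ccc(/C(=N\O)c2ccccc2)cc1)C(F)(F)F` likewise sits at the limit of this assay, > 30000 nM. Compound 2 thus stands at the weak end of what has been measured, sharing the limit of > 30000 nM in this assay, at which 2 of the 3 values shown sit, with compound 3, while compound 1 alone has a measured number.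

Among the compounds with values here, the one measured step that connects two of them is an at least 62-fold higher number from compound 1 to compound 2 (1.79 log units; beyond the scatter), a large loss upon exchanging a sulfamoyl group for a carbamoyl group.

Compound 4 `CCN(CC)S(=O)(=O)c1ccc(NC(=O)C(C)(O)C(F)(F)F)cc1` has not yet been measured. It differs from compound 2 in one place: diethylsulfamoyl in place of diethylcarbamoyl on an aromatic carbon. This brings back a sulfamoyl group of the kind present in compound 1, while keeping the diethyl substitution of compound 2. The step from compound 1 to compound 2 bears directly on it. Only a limit is known for compound 2, and the exact size of the return cannot be read off. Still, a step toward a lower number, beyond the scatter, is expected: an at least 20-fold lower number from compound 2 to compound 4 (1.30 log units; beyond the scatter). The estimate for compound 4 in this assay is 1500 nM, with a likely range from 300 nM to 10000 nM.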

Compound 4, half-maximal inhibitory concentration: 810 nM
The estimate for compound 4 lay 1.9-fold (0.27 log units) above the measured number; low and high end bracket the measured number.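

Compound 4 pulls apart two differences that compound 1 and compound 2 carried together. With the diethyl substitution kept, exchanging diethylcarbamoyl for diethylsulfamoyl on this aromatic carbon in this assay brings an at least 37-fold lower number from compound 2 to compound 4 (1.56 log units; beyond the scatter), whereas diethylamino in place of dimethylamino on the sulfonyl sulfur gives a 1.7-fold higher number from compound 1 to compound 4 (0.23 log units; within the scatter), so among these compounds the large loss goes with the carbamoyl group and not with the ethyl groups. Compound 2 holds only a limit and not a number, so the full size of the step from it stays unknown: the limit of > 30000 nM in this assay, at which 2 of the 4 values shown sit.

Going by these compounds, what remains open is how far the amine part on the sulfonyl sulfur can be changed, for instance whether a longer chain such as dipropylamino would stay in the range of compound 1 and compound 4 or fall away as compound 2 does. Also open, on these data alone, is whether a plain amino group on the sulfur, with no alkyl chains at all, would hold up, and these data do not tell why the carbamoyl group fares so much worse.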